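Phenyl for Methylpyridinyl on an Inactive Lactam

A few compounds are considered here, and "the series" means these few. Any claim that something is new, unique, unknown or untested is made for them only; others in the source may bear on it.

Compound 3 `Cc1cccc(-c2noc(C3CC(=O)N(c4ccc(F)cc4)C3)n2)n1` stands at the bottom of the numbers shown. In an in vitro functional assay on HEK293-A cells for positive allosteric modulation of metabotropic glutamate receptor 5 (Homo sapiens), read by FLIPR and calcium flux (a lower number here means that less compound is needed, a higher number that more compound is needed for the effect), compound 3 gives only a limit, > 10000 nM, and no number. That value is the limit of > 10000 nM in this assay, at which 1 of the 3 values shown sits. Two related compounds carry numbers: compound 1 `O=C1CC(c2nc(-c3cccc(Cl)c3)no2)CN1c1ccc(Cl)c(Cl)c1` gives 460 nM in this assay, and compound 2 `O=C1CC(c2nc(-c3ccc(Cl)cc3)no2)CN1c1ccc(Cl)c(Cl)c1` gives 1100 nM in this assay. Going by the values given here, the one measured step between them is a 2.4-fold higher number from compound 1 to compound 2 (0.38 log units; beyond the scatter), a shift of a chlorine on the aryl group of the oxadiazole.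

Compound 4 `O=C1CC(c2nc(-c3ccccc3)no2)CN1c1ccc(F)cc1` differs from compound 3 in one place: phenyl in place of 6-methylpyridin-2-yl on an aromatic carbon. Among the compounds with values here, no measured step concerns this exchange; the step from compound 1 to compound 2 shows only that moving a substituent on this aryl ring gives a modest change, and it says nothing about swapping a pyridinyl for a phenyl. Since compound 3 rests on a limit, any step from it is uncertain, and the expected step is an at least 2.0-fold lower number from compound 3 to compound 4 (0.30 log units; that floor lies within the scatter), towards a measurable number but without confidence. Compound 4 is therefore estimated at 5000 nM in this assay, with a range from 1000 nM to 20000 nM, and a real chance that only a limit is reported again.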

Compound 4, half-maximal effective concentration: 58 nM
For compound 4 the middle estimate is 86-fold (1.94 log units) above the measured one; the whole stated range lies above it.
By their numbers in this assay, from the lowest: compound 4; then compound 1; then compound 2. At a limit, above all of these: compound 3.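

At this aromatic carbon, between two ring nitrogen atoms, the exchange of 6-methylpyridin-2-yl for phenyl produces a large change in this assay: an at least 170-fold lower number from compound 3 to compound 4 (2.23 log units; beyond the scatter). The earlier compounds shown here showed only a modest change when a chlorine moved on this aryl ring, whereas this step shows that the identity of the ring itself can separate a limit from a measured number. Compound 3 gives a limit and not a number, so the step is only a floor and its full size stays unknown: the limit of > 10000 nM in this assay, at which 1 of the 4 values shown sits.

The exchange removes a ring nitrogen and a methyl group together, and the compounds shown do not tell which of the two accounts for the step; an unsubstituted pyridinyl or a methylphenyl group at this carbon would separate them. Also open, on these data alone, are whether the same exchange gives a step of this size on the core of compound 1, and how a methoxy group or an amine on the phenyl of compound 4 would read in this assay.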